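Chloro for fluoro on the aryl urea, meta case

This account rests on a few compounds, and the source may have more. Where it says the series, first, only, none or still open, it means among the compounds named here.

Compound 1 `C[C@H](NC(=O)Nc1ccccc1F)c1ccccc1` is the starting point of the series. In an ADME assay on the whole organism with Oryza sativa as the target, tested at 1 uM (on this read-out higher numbers stand for a weaker effect at the one concentration tested and lower numbers for a stronger effect), compound 1 gives 92%. Among the compounds with values here, compound 3 `C[C@H](NC(=O)Nc1ccccc1Cl)c1ccccc1` carries the change chloro in place of fluoro on an aromatic carbon and in this assay compound 3 gives 104%; the step of a number 12 percentage points higher from compound 1 to compound 3 (beyond the scatter) is the only measured step. Compound 2 `C[C@@H](NC(=O)Nc1cccc(F)c1)c1ccccc1` has the same atoms as compound 1 joined differently; the difference between the two cores is not broken down here. In this assay compound 2 gives 95%, a number that lies within the scatter of compound 1 and of compound 3, so no order among the three can be read from it.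

Compound 4 `C[C@@H](NC(=O)Nc1cccc(Cl)c1)c1ccccc1` has not been measured. It stands to compound 2 as compound 3 stands to compound 1: the change is chloro in place of fluoro on an aromatic carbon. The place differs, however: in compound 3 the chloro sits ortho to a large group, in compound 4 it sits meta to a large group, so this is the same kind of change and not the same change. Within the data shown here, the expectation for this assay rests on the one measured step, a number 12 percentage points higher from compound 1 to compound 3 (beyond the scatter), and the step from compound 2 to compound 4 is expected to be a number 9 percentage points higher from compound 2 to compound 4 (within the scatter), of a similar size. Compound 4 is therefore expected to give about 104% in this assay, with a likely range from 93% to 115%.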

Compound 4, a percentage reported as activity, at one concentration (the size of the read-out at that concentration, not a potency): 91%
Compound 4: the middle estimate sits 13 percentage points above what was measured; the measured number lies below the stated range.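

In this assay, the step for chloro in place of fluoro on an aromatic carbon does not carry over from one core to the other: the same change on two cores in this assay, a number 12 percentage points higher (beyond the scatter) from compound 1 to compound 3 and a number 4 percentage points lower (within the scatter) from compound 2 to compound 4, 16 percentage points apart, beyond the scatter of two such steps The new step reads a number 4 percentage points lower from compound 2 to compound 4 (within the scatter), so with the chloro meta to a large group, the pair shows no difference that can be read on this measure, and the step seen on the core of compound 1 is not a reliable guide to the core of compound 2. This does not show why the two steps part, since there is one pair per core and the result cannot separate the place of the halogen from any other difference between the cores, nor does it show that the change would behave either way on a further core.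

The compounds shown carry only fluoro or chloro on the aromatic ring of the urea, so it remains open whether a nitrile, a methoxy or a trifluoromethyl group meta to a large group would track either step. Going by these compounds, it is equally open how an amine or a carboxylic acid on that ring would read in this assay.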